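The source may report more compounds than this note shows. Statements on the series, on what has been measured and on what is new or still open speak of the compounds shown alone.

Going by the values given here, in an ADME assay on L6 cells (Rattus norvegicus) for cytotoxicity (on this read-out lower numbers stand for stronger inhibition and higher numbers for weaker inhibition), compound 2 `COc1cc(C(=N)NC(C)C)ccc1-c1cc2cc(C(=N)NC(C)C)ccc2o1` gives 98100 nM, the only actual number available so far. Compound 1 `CC(C)NC(=N)c1ccc(-c2cc3cc(C(=N)NC(C)C)cc(O)c3o2)c(O)c1` is reported as > 179000 nM, which is a limit of the assay and not a number. Compound 3 `CC(C)NC(=N)c1ccc(-c2cc3cc(C(=N)NC(C)C)ccc3o2)c(O)c1` is the next compound to be considered. It differs from compound 2 by hydrogen in place of methyl on an oxygen on an aromatic ring, with hydrogen in place of methyl on an oxygen on an aromatic ring, so that methoxy becomes hydroxy. Among the compounds with values here, no measured pair shows what this change does in this assay, so any forecast remains uncertain. Starting from compound 2 at 98100 nM, no step beyond the usual scatter is expected, and no firm direction is assumed. The expected step is a 1.1-fold higher number from compound 2 to compound 3 (0.03 log units; within the scatter). Compound 3 is estimated at 105000 nM, with an expected range of 40000 nM to 220000 nM.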

Compound 3, half-maximal inhibitory concentration: > 183000 nM
Compound 3 was reported as a limit; the forecaster's own chance of this, stated with the estimate: 30%; at least 1.7-fold (0.24 log units) between middle value and limit.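

Going from methoxy to hydroxy on an oxygen on an aromatic ring now has a readable outcome, with an at least 1.8-fold higher number from compound 2 to compound 3 (0.27 log units; that floor lies within the scatter). In this assay this points towards weaker inhibition, although the floor of the step does not by itself pass the scatter. As far as these compounds go, the full size of the step remains unknown because compound 3 stands at a limit of the assay and not at a number: the limit of > 183000 nM in this assay, at which 1 of the 3 values shown sits.

The step between compound 1 and compound 3, where hydrogen takes the place of hydroxy on an aromatic carbon, cannot be read: both values are limits. From the compounds shown here alone, it also remains open what a longer chain such as ethoxy on that oxygen, or an amine in place of the methoxy, would do in this assay.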